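This account rests on a few compounds, and the source may have more. Where it says the series, first, only, none or still open, it means among the compounds named here.

Measured so far in an ADME assay on HEK293 cells (Homo sapiens) for cytotoxicity, read by MTT assay, with a stated time of 72 h; a higher number here means that more compound is needed for the effect, a lower number that less compound is needed:
compound 1 `O=C(O)c1cn(C2CC2)c2cc(N3CCN(Cn4nc(-c5ccccc5O)n(Cc5ccccc5)c4=S)CC3)c(F)cc2c1=O` gives 69100 nM
compound 2 `COc1ccc(Cn2c(-c3ccccc3O)nn(CN3CCN(c4cc5c(cc4F)c(=O)c(C(=O)O)cn5C4CC4)CC3)c2=S)cc1` gives 78700 nM
compound 3 `O=C(O)c1cn(C2CC2)c2cc(N3CCN(Cn4nc(-c5cccc(O)c5)n(-c5ccccc5)c4=S)CC3)c(F)cc2c1=O` gives 140000 nM

Compound 3 holds the highest of the three numbers in this assay; its gap to compound 2 is within the scatter, and only its gap to compound 1 lies beyond it. Among the compounds with values here, the one single-point step measured, a 1.1-fold higher number from compound 1 to compound 2 (0.06 log units; within the scatter), changes nothing beyond the scatter.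

Compound 4 `O=C(O)c1cn(C2CC2)c2cc(N3CCN(Cn4nc(-c5cccc(O)c5)n(Cc5ccc(F)cc5)c4=S)CC3)c(F)cc2c1=O` is not yet measured. It differs from compound 3 by 4-fluorobenzyl in place of phenyl on an aromatic nitrogen. Within the data shown here, compounds 1 and 2 carry a benzyl or 4-methoxybenzyl group on that same ring nitrogen, but each of them also differs from compound 3 in the hydroxyphenyl group, so no single-point step covers the phenyl-to-benzyl exchange; their values in this assay show only that benzyl-bearing and phenyl-bearing members all sit within a narrow band. Among the measured compounds shown here, the one measured step, a 1.1-fold higher number from compound 1 to compound 2 (0.06 log units; within the scatter), suggests that substitution on that benzyl ring moves the number little.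

The expectation for compound 4 in this assay is therefore a step of a 1.3-fold lower number from compound 3 to compound 4 (0.10 log units; within the scatter), that is, no change beyond the scatter. Compound 4 is estimated at 110000 nM, within 55000 nM to 220000 nM.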

Compound 4, half-maximal effective concentration: 69500 nM
Compound 4: middle estimate off by 1.6-fold (0.20 log units), on the high side; low and high end bracket the measured number.
By their numbers in this assay, from the lowest: compounds 1, 4, 2 and 3 (each within the scatter of the next, the first and the last beyond it).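

In this assay, within the data shown here, the exchange of phenyl for 4-fluorobenzyl is the first single-place step read at the aromatic nitrogen itself, and it gives a 2.0-fold lower number from compound 3 to compound 4 (0.30 log units; within the scatter), so the exchange registers no change beyond the scatter. The earlier step altered only a substituent on a benzyl ring already in place, whereas this one replaces the group bound to the nitrogen next to the ring atom that bears a 3-hydroxyphenyl group, and the cytotoxicity number still holds within the scatter for this pair. No supporting data are available to explain this result.

The step combines two differences, the benzyl link and the fluorine, and the compounds shown do not separate them, since no single-place step isolates either one with the 3-hydroxyphenyl group present. Also open, as far as these compounds go, is whether a longer chain between the nitrogen and the aromatic ring, or an amine or a carboxylic acid carried on that nitrogen, would keep the number within the scatter of compound 3.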